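Furan-to-thiophene swap on the shared core

A few compounds are considered here, and "the series" means these few. Any claim that something is new, unique, unknown or untested is made for them only; others in the source may bear on it.

In a functional assay on K562 cells (Homo sapiens), read by MTT assay, with a stated time of 72 h (a higher number here means a weaker inhibitor, a lower number a stronger inhibitor), compound 3 `COc1ncnc2c1c(-c1ccco1)cn2[C@@H]1O[C@H](CO)[C@@H](O)[C@H]1O` gives 60 nM, the lowest of the two numbers in hand. Compound 1 `C#Cc1cn([C@@H]2O[C@H](CO)[C@@H](O)[C@H]2O)c2ncnc(OC)c12` gives 300 nM, and the measured step of a 5.0-fold lower number from compound 1 to compound 3 (0.70 log units; beyond the scatter) separates the two. Compound 2 `CNc1ncnc2c1c(-c1ccsc1)cn2[C@@H]1O[C@H](CO)[C@@H](O)[C@H]1O` gives > 20000 nM, which is a limit and not a number, sitting at the limit of > 20000 nM in this assay, at which 1 of the 3 values shown sits. Compound 4 `COc1ncnc2c1c(-c1ccsc1)cn2[C@@H]1O[C@H](CO)[C@@H](O)[C@H]1O` is not yet measured in this assay and differs from compound 3 by thiophen-3-yl in place of furan-2-yl on an aromatic carbon. Compound 2 also carries thiophen-3-yl, but it differs from compound 4 at a second place as well, so its limit says nothing direct about the present change. Within the data shown here, no measured step exchanges one five-membered aromatic ring with one hetero atom for another, and the step from ethynyl to furan-2-yl does not reach this change. With nothing measured that bears on it, the swap is expected to move the number little, if at all, beyond the scatter. Compound 4 is therefore expected to give 100 nM, within 30 nM to 400 nM, which would mean a step of a 1.7-fold higher number from compound 3 to compound 4 (0.22 log units; within the scatter).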

Compound 4, half-maximal inhibitory concentration: 90 nM
Compound 4: middle estimate off by 1.1-fold (0.05 log units), on the high side; the measured number falls inside the stated range.
By their numbers in this assay, from the lowest: compounds 3 and 4 (each within the scatter of the next); then compound 1. At a limit, above all of these: compound 2.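

In this assay, furan-2-yl and thiophen-3-yl cannot be told apart at this aromatic carbon, with a 1.5-fold higher number from compound 3 to compound 4 (0.18 log units; within the scatter). Thiophen-3-yl also goes the same way as furan-2-yl against ethynyl, with a 3.3-fold lower number from compound 1 to compound 4 (0.52 log units; beyond the scatter). With thiophen-3-yl held fixed, the other place on the shared core carries far more weight, as methoxy in place of methylamino gives an at least 220-fold lower number from compound 2 to compound 4 (2.34 log units; beyond the scatter), a step that rests on the value of compound 2, which is a limit and not a number: the limit of > 20000 nM in this assay, at which 1 of the 4 values shown sits.

Open, going by these compounds, is whether the match between the two rings holds for thiophen-2-yl, furan-3-yl or a six-membered ring such as phenyl at this carbon. Also open, on these data alone, is whether ethoxy, or an amine such as dimethylamino, in place of methoxy would stay with compound 4 or fall towards compound 2.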